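A few compounds are considered here, and "the series" means these few. Any claim that something is new, unique, unknown or untested is made for them only; others in the source may bear on it.

Three measured compounds share one core and differ only in the ring attached to a nitrogen on the aromatic ring. Compound 1 `O=C(N[C@@H](CCC(=O)N1CCN(c2cccc(NC3=NCCN3)c2)CC1)C(=O)O)OCc1ccccc1` gives 3 nM in a functional assay (muscle tissue) for inhibition, with Homo sapiens as the target; on this read-out lower numbers stand for stronger inhibition and higher numbers for weaker inhibition. Compound 2 `O=C(N[C@@H](CCC(=O)N1CCN(c2cccc(NC3=NCCCN3)c2)CC1)C(=O)O)OCc1ccccc1` gives 1.1 nM and stands at the lowest number of the three. Compound 3 `O=C(N[C@@H](CCC(=O)N1CCN(c2cccc(NC3=NCC(O)CN3)c2)CC1)C(=O)O)OCc1ccccc1` gives 3.5 nM. The steps are modest: a 2.7-fold lower number from compound 1 to compound 2 (0.44 log units; beyond the scatter), a 1.2-fold higher number from compound 1 to compound 3 (0.07 log units; within the scatter) and a 3.2-fold higher number from compound 2 to compound 3 (0.50 log units; beyond the scatter).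

Compound 4 `CCOC(=O)N[C@@H](CCC(=O)N1CCN(c2cccc(NC3=NCCCN3)c2)CC1)C(=O)O` is not yet measured. It keeps the ring of compound 2 and changes a different part: methyl in place of phenyl on a saturated chain carbon bound to an oxygen next to a carbonyl group. None of the three measured steps touches this position; all of them concern the ring on the aromatic nitrogen, so they give no direct guide to the size or direction of this step. What can be said is that the measured changes elsewhere on this core moved the numbers only modestly. The expectation is therefore a small step, a 2.7-fold higher number from compound 2 to compound 4 (0.44 log units; beyond the scatter), with wide uncertainty in both directions. Compound 4 is estimated at 3 nM, in a range from 0.8 nM to 12 nM.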

Compound 4, half-maximal inhibitory concentration: 2.1 nM
For compound 4 the middle estimate is 1.4-fold (0.15 log units) above the measured one; measured number inside the range.
By their numbers in this assay, from the lowest: compounds 2, 4, 1 and 3 (each within the scatter of the next, the first and the last beyond it).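

For the compounds shown here, this is the first change on the shared core away from the ring on the aromatic nitrogen. In this assay, replacing benzyloxycarbonyl with ethoxycarbonyl gives a 1.9-fold higher number from compound 2 to compound 4 (0.28 log units; within the scatter), so for this one pair the phenyl and its six-membered aromatic ring are not required for a low number, and methyl can take their place without a change that can be told apart from the scatter. Nothing available explains why this position accepts the swap.

The compounds shown leave open whether this position would also accept a quite different group, such as an amine or a carboxylic acid at the end of a longer chain. They also leave open whether ethoxycarbonyl would behave the same way alongside the ring of compound 1 or compound 3.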